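The source may report more compounds than this note shows. Statements on the series, on what has been measured and on what is new or still open speak of the compounds shown alone.

Working notes on the styryl sulfone series around a shared core.

In a functional assay on DU-145 cells (Homo sapiens) for cytotoxicity, read by trypan blue exclusion, with a stated time of 96 h (on this read-out higher numbers stand for weaker inhibition and lower numbers for stronger inhibition), compound 1 `COc1cc(OC)c(/C=C/S(=O)(=O)Cc2ccc(OC)cc2[N+](=O)[O-])c(OC)c1` gives 20000 nM, and compound 2 `COc1cc(OC)c(/C=C/S(=O)(=O)Cc2ccc(Br)c([N+](=O)[O-])c2)c(OC)c1` gives 25000 nM. Compound 3 `COC(=O)CCNc1cc(CS(=O)(=O)/C=C/c2c(OC)cc(OC)cc2OC)ccc1OC` gives 1500 nM in this assay, the lowest of the three numbers; its gaps to compound 1 and to compound 2 both lie beyond the scatter, so compound 3 stands as the strongest inhibitor of the three measured compounds.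

Compound 4 `COc1ccc(C(Nc2cc(CS(=O)(=O)/C=C/c3c(OC)cc(OC)cc3OC)ccc2OC)C(=O)O)cc1` has not been measured. It differs from compound 3 in one place: carboxy(4-methoxyphenyl)methyl in place of 2-(methoxycarbonyl)ethyl on a nitrogen on an aromatic ring. Within the data shown here, no measured pair shows this change, so its effect cannot be read from the numbers at hand. The expectation for this assay is a step of a 2.0-fold higher number from compound 3 to compound 4 (0.30 log units; within the scatter) that is small, in the direction of weaker inhibition, and not clearly beyond the scatter. The starting point for this estimate is compound 3 at 1500 nM. Compound 4 is therefore expected to give about 3000 nM, within a range of 800 nM to 12000 nM.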

Compound 4, half-maximal inhibitory concentration: 100 nM
Compound 4: middle estimate off by 30-fold (1.48 log units), on the high side; the whole stated range lies above it.
By their numbers in this assay, from the lowest: compound 4; then compound 3; then compounds 1 and 2 (each within the scatter of the next).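

Among these compounds, the group on the nitrogen on an aromatic ring turns out to be a sensitive position in this assay, which the earlier compounds could not show, as none of them differed in one place. Replacing 2-(methoxycarbonyl)ethyl with carboxy(4-methoxyphenyl)methyl gives a 15-fold lower number from compound 3 to compound 4 (1.18 log units; beyond the scatter), a large step towards stronger inhibition, so this position accepts a larger group that brings a six-membered aromatic ring of carbon only and a hydrogen-bond donor. Nothing at hand accounts for the size of this step.

The change brings in the carboxy group and the 4-methoxyphenyl ring together, so the step cannot be divided between them. A benzyl group or a carboxymethyl group on the same nitrogen would carry only one of these features and would separate their contributions.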